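Fluorine Enters the Hydroxyphenyl Group of Compound 1

The compounds below may be only part of what the source reports. "The series", "measured", "known", "first", "only" and "open" are said of these compounds alone.

Going by the values given here, compound 1 `CC(C)(C)C1=NN(c2cccc(Cl)c2)C(c2ccc(O)cc2)C1` is the only member of this small set with a number: in an assay on isolated protein for inhibition of protein kinase C zeta type (Homo sapiens), with a stated time of 4 min (on this read-out lower numbers stand for stronger inhibition and higher numbers for weaker inhibition), compound 1 gives 5200 nM. Compound 2 `Cc1ccc(N2N=C(C(C)(C)C)CC2c2ccc(O)cc2)c(C)c1` has in this assay only the entry "not determined" (no result reported), and compound 3 `CC(C)(C)C1=NN(c2ccc(O)cc2)C(c2ccc(O)cc2)C1` has in this assay only the entry "not determined" (no result reported), so compound 1 cannot be placed against them. Compound 4 `CC(C)(C)C1=NN(c2cccc(Cl)c2)C(c2ccc(F)c(O)c2)C1` differs from compound 1 in one place: 4-fluoro-3-hydroxyphenyl in place of 4-hydroxyphenyl on a saturated ring carbon. Among the compounds with values here, no measured pair in this set shows such a change, so the step is expected to be small and without a clear direction, probably within the usual scatter, as expressed by a 1.2-fold higher number from compound 1 to compound 4 (0.06 log units; within the scatter). Compound 4 is therefore expected to give 6000 nM in this assay, with a range from 1500 nM to 25000 nM.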

Compound 4, half-maximal inhibitory concentration: 300 nM
Beside the measured number, compound 4's estimate is 20-fold (1.30 log units) above it, outside the stated range (below it).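

On this saturated ring carbon of the core, the swap to 4-fluoro-3-hydroxyphenyl gives a 17-fold lower number from compound 1 to compound 4 (1.24 log units; beyond the scatter) in this assay, so this position responds strongly to a change in the aryl group. Going by these compounds alone, the single swap both brings in fluorine and changes the hydroxy placement, so the step cannot be split between them. Nothing measured here accounts for the size of this step. Still open, on these data alone, is whether 3-hydroxyphenyl without the fluorine, or 4-fluorophenyl without the hydroxy group, would give a similar step. An amine in place of the hydroxy group also remains untested among the compounds shown.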